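Methyl on the pendant phenyl of the fused core

A few compounds are considered here, and "the series" means these few. Any claim that something is new, unique, unknown or untested is made for them only; others in the source may bear on it.

Measured so far:
compound 1, `O=C(C=CNc1cc(-c2ccccc2)nn1-c1ccccc1)c1cccs1`, 15400 nM
compound 2, `O=C(C=CNc1cc(-c2ccccc2)nn1-c1ccccc1)c1ccccc1`, 9650 nM
compound 3, `c1ccc(-c2ccnc3c2c(-c2ccccc2)nn3-c2ccccc2)cc1`, 28200 nM

In a functional assay on MCF7 cells (Homo sapiens) for inhibition, read by MTT assay, with a stated time of 48 h (a lower number here means a stronger inhibitor, a higher number a weaker inhibitor), compound 3 gives 28200 nM, the largest number of the three, though its gap to compound 1 at 15400 nM lies within the scatter; only the gap to compound 2 at 9650 nM lies beyond it.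

Compound 4, `Cc1ccc(-c2ccnc3c2c(-c2ccccc2)nn3-c2ccccc2)cc1`, differs from compound 3 by methyl in place of hydrogen on an aromatic carbon. Going by the values given here, the single measured step, a 1.6-fold lower number from compound 1 to compound 2 (0.20 log units; within the scatter), concerns a carbonyl substituent on the other core of the series and was within the scatter; no measured step concerns a methyl on an aromatic carbon, so nothing bears directly on this change. The expectation is therefore a step of no size beyond the scatter, in either direction, with a 1.1-fold lower number from compound 3 to compound 4 (0.05 log units; within the scatter) as the estimated step. Compound 4 is estimated at 25000 nM, with a range from 9000 nM to 70000 nM.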

Compound 4, half-maximal inhibitory concentration: 5590 nM
The estimate for compound 4 lay 4.5-fold (0.65 log units) above the measured number; the whole stated range lies above it.
By their numbers in this assay, from the lowest: compounds 4, 2, 1 and 3 (each within the scatter of the next, the first and the last beyond it).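

In this assay, going by these compounds alone, the change from phenyl to 4-methylphenyl on the fused core gives a 5.0-fold lower number from compound 3 to compound 4 (0.70 log units; beyond the scatter) and is the only one-place change that moves the number beyond the scatter. Within the data shown here, the sole earlier step, a 1.6-fold lower number from compound 1 to compound 2 (0.20 log units; within the scatter), stayed within the scatter and concerned a carbonyl substituent on the other core, so this is the first sign that the series responds to a single added methyl, para to a large group. No measurement available accounts for the size of this step.

On these data alone, whether the step belongs to methyl itself or would also appear with an ethyl chain, a methoxy group, chlorine or an amine on the same carbon remains open. Also open, as far as these compounds go, is whether a methyl would do the same on the phenyl groups of the core of compound 2.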